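This account rests on a few compounds, and the source may have more. Where it says the series, first, only, none or still open, it means among the compounds named here.

Among the measured compounds shown here, in a functional assay on A2780 cells (Homo sapiens) for antiproliferative activity, read by sulforhodamine B assay, with a stated time of 48 h (on this read-out higher numbers stand for weaker inhibition and lower numbers for stronger inhibition), compound 1 `COc1ccc(/C=C/C(=O)c2ccccc2-c2ccc(F)cc2)cc1O` gives 27 nM, the lowest number of the three compounds measured so far. Compound 2 `COc1ccc(/C=C/C(=O)c2ccccc2-c2ccc(F)cc2)cc1B(O)O` gives 63 nM, and compound 3 `CN(C)c1ccc(/C=C/C(=O)c2ccccc2-c2ccc(F)cc2)cc1` gives 94 nM.

The next compound to consider is compound 4 `COc1ccc(/C=C/C(=O)c2ccccc2-c2cccc(F)c2)cc1O`, which has the same atoms as compound 1, joined differently: 3-fluorophenyl in place of 4-fluorophenyl on an aromatic carbon. The two groups that trade places differ only in where the fluorine sits on the ring, and the rest of the molecule stays the same.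

The measurements offer little direct guidance. For the measured compounds named here, the only measured step that changes one place in the structure is a 2.3-fold higher number from compound 1 to compound 2 (0.37 log units; beyond the scatter). Going by the values given here, this step is modest but beyond the scatter, and it concerns a different place from the one altered in compound 4. Among the compounds with values here, no measured compound carries the 3-fluorophenyl group, so the direction of the change remains uncertain. Compound 1 already lies at the low end at 27 nM, so a slight rise seems a little more likely than a fall. The expected change is small, a 1.5-fold higher number from compound 1 to compound 4 (0.17 log units; within the scatter), and may not exceed the scatter. For compound 4 the estimated value is 40 nM, with an expected range from 15 nM to 110 nM.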

Compound 4, half-maximal inhibitory concentration: 13 nM
Compound 4: middle estimate off by 3.1-fold (0.49 log units), on the high side; measured number below the stated range.
By their numbers in this assay, from the lowest: compound 4; then compound 1; then compounds 2 and 3 (each within the scatter of the next).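

In this assay, exchanging 4-fluorophenyl for 3-fluorophenyl gives a 2.1-fold lower number from compound 1 to compound 4 (0.32 log units; beyond the scatter), a modest step but one beyond the usual scatter. Among the compounds shown here, the earlier step concerned a different place in the molecule, so this is the first sign that the number also responds to a change at this position, even when the atoms stay the same and only the location of the fluorine differs. The available data contain no measured property that could explain the difference between the two fluorophenyl groups.

From the compounds shown here alone, the comparison covers only these two fluorine locations, so it remains open how a plain phenyl group, 2-fluorophenyl, 3-chlorophenyl or 3-methoxyphenyl would compare at this position, and therefore whether the lower number is specific to fluorine. Going by these compounds, it is also open whether placing 3-fluorophenyl on compound 2 or compound 3 would lower their numbers in the same way, or whether this step holds only alongside the groups carried by compound 1.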